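Swapping one halogen-bearing ring for another

The source may hold more compounds than are shown below. What is called first, only, known or untested is meant among the compounds shown, and "the series" means these compounds.

Measured in a functional assay on NCI-H520 cells (Homo sapiens); on this read-out higher numbers stand for weaker inhibition of growth and lower numbers for stronger inhibition of growth
compound 1 `N#Cc1ccc(/C=C/S(=O)(=O)Cc2ccc(Nc3ncnc4ccccc34)cc2)cc1` gives > 100000 nM
compound 2 `O=S(=O)(/C=C/c1ccc(Cl)c(Cl)c1)Cc1ccc(Nc2ncnc3ccccc23)cc1` gives 32000 nM
compound 3 `CC(C)(C)c1cc(/C=C/S(=O)(=O)Cc2ccc(Nc3ncnc4ccccc34)cc2)cc(C(C)(C)C)c1O` gives 45000 nM

The entry for compound 1 of > 100000 nM is a limit of this assay and not a number. For the measured compounds named here, compound 2 gives 32000 nM as one of only two true numbers, and compound 3 at 45000 nM lies within the scatter of it, so the two cannot be told apart.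

Compound 4 `O=S(=O)(/C=C/c1ccc(F)cc1Cl)Cc1ccc(Nc2ncnc3ccccc23)cc1` differs from compound 2 in one group (2-chloro-4-fluorophenyl in place of 3,4-dichlorophenyl on a double-bonded chain carbon bound to a double-bonded chain carbon): 2-chloro-4-fluorophenyl stands in place of 3,4-dichlorophenyl, and each is a six-membered aromatic ring of carbon only.

Going by the values given here, the one measured step that exchanges a single group at this place runs an at least 3.1-fold lower number from compound 1 to compound 2 (0.49 log units; beyond the scatter) and lies beyond the scatter. It replaces 4-cyanophenyl and rests on a limit (the limit of > 100000 nM in this assay, at which 1 of the 3 values shown sits), so it sets no size for an exchange between two chlorine-bearing rings.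

In this assay the expected change is a 1.3-fold higher number from compound 2 to compound 4 (0.10 log units; within the scatter) and no step beyond the scatter is expected. For compound 4 the estimate is 40000 nM with 15000 nM to 90000 nM as its expected range.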

Compound 4, concentration for 50% growth inhibition: 100000 nM
Compound 4: the middle estimate sits 2.5-fold (0.40 log units) below what was measured, outside the stated range (above it).
By their numbers in this assay, from the lowest: compounds 2 and 3 (each within the scatter of the next); then compound 4.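

Exchanging one chlorine-bearing ring for another at this place is not a neutral swap: in this assay 2-chloro-4-fluorophenyl in place of 3,4-dichlorophenyl gives a 3.1-fold higher number from compound 2 to compound 4 (0.49 log units; beyond the scatter) and so a weaker inhibition of growth. For the compounds shown here, this is the first exchange here with a true number at both ends, and it happens although both rings have the same count of heavy atoms and neither has a hydrogen-bond donor or acceptor. Compound 1 carries a limit and not a number. 2-chloro-4-fluorophenyl in place of 4-cyanophenyl gives a number no higher from compound 1 to compound 4 (the limit leaves the size open), so the size of this step cannot be read: the limit of > 100000 nM in this assay, at which 1 of the 4 values shown sits.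

The two group names differ in more than one respect, and the compounds shown do not separate the effect of the fluorine from that of where the chlorine stands. On these data alone, how an amine, a carboxylic acid or a longer chain at this place would read also stays open.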